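From pyridin-4-yl to pyridin-3-yl

The compounds below may be only part of what the source reports. "The series", "measured", "known", "first", "only" and "open" are said of these compounds alone.

In an ADME assay on HeLa Rh cells (Homo sapiens) for cytotoxicity, read by microscopy (on this read-out lower numbers stand for higher toxicity in this test and higher numbers for lower toxicity in this test), compound 1 (`COc1cc(CC(O)c2ccc(-c3cccc(CO)c3)cc2)c([N+](=O)[O-])cc1OC`) gives 6000 nM as a measured number. Compound 2 (`COc1cc(CC(O)c2ccc(-c3ccncc3)cc2)c([N+](=O)[O-])cc1OC`) gives > 263000 nM as a limit of the assay and not a number. Compound 2 therefore sits at the limit of > 263000 nM in this assay, at which 1 of the 2 values shown sits, and has no exact value.

Compound 3 (`COc1cc(CC(O)c2ccc(-c3cccnc3)cc2)c([N+](=O)[O-])cc1OC`) carries pyridin-3-yl in place of pyridin-4-yl on an aromatic carbon, para to a large group (pyridin-3-yl in place of pyridin-4-yl on an aromatic carbon). The two have the same atoms, joined differently. For the measured compounds named here, the only measured step that bears on this change is an at least 43-fold higher number from compound 1 to compound 2 (1.64 log units; beyond the scatter) and it is large, beyond the scatter. That step exchanged one group for a different one, so it offers only weak guidance for a change that keeps the same atoms. In this assay no step beyond the scatter is expected here. The estimated change is an at least 1.4-fold lower number from compound 2 to compound 3 (0.16 log units; that floor lies within the scatter) and it is expected to stay within the scatter. For compound 3 the estimated value is 180000 nM with an expected range from 40000 nM to 300000 nM in this read-out, and another limit is quite possible.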

Compound 3, half-maximal cytotoxic concentration: > 263000 nM
Compound 3: a limit, no number; the forecaster's own chance of this, stated with the estimate: 50%; middle value at least 1.4-fold (0.16 log units) from the limit.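

In this assay, compound 3 ends at a limit of the assay and not at a number, just as compound 2 does, so moving from pyridin-4-yl to pyridin-3-yl leaves the read-out at the same limit: the limit of > 263000 nM in this assay, at which 2 of the 3 values shown sit.

Replacing the 3-(hydroxymethyl)phenyl of compound 1 with pyridin-3-yl gives an at least 43-fold higher number from compound 1 to compound 3 (1.64 log units; beyond the scatter), so the large step seen earlier is not confined to pyridin-4-yl but appears with both pyridines shown. The step between the two pyridines cannot be read, since both compounds sit at a limit, and nothing can be said about any order between them in this assay.

The compounds shown leave open whether the large step belongs to the pyridine rings themselves or to the loss of the hydroxymethyl group, since compound 1 differs from each pyridine in both the ring and that group. A plain phenyl ring, a pyridin-2-yl ring or a phenyl ring bearing a carboxylic acid at this place would help to separate these readings, and only a read-out that gives numbers could show whether the two pyridines differ at all.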